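The compounds below may be only part of what the source reports. "The series", "measured", "known", "first", "only" and "open" are said of these compounds alone.

Measured compounds:
compound 1 `O=C(Nc1cccc(-n2cc(-c3ccncc3)c(-c3cc(O)cc(Cl)c3)n2)c1)Nc1ccc(Cl)c(C(F)(F)F)c1` gives 101%
compound 2 `O=C(Nc1cccc(-n2cc(-c3ccncc3)c(-c3cc(O)cc(Cl)c3)n2)c1)Nc1ccc(Cl)c(Cl)c1` gives 103%

In a functional assay on RPMI-8226 cells (Homo sapiens) for inhibition, read by sulforhodamine B assay, with a stated time of 48 h, tested at 0.1 uM (a higher number here means a weaker effect of the compound at the concentration tested, a lower number a stronger effect), compound 1 gives 101%, which stands as the lowest of the two numbers, but the step of a number 2 percentage points higher from compound 1 to compound 2 (within the scatter) is within the scatter, so the two compounds cannot be told apart on this read-out. Both numbers sit at essentially the level of untreated cells.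

Compound 3 `COc1cc(Cl)cc(-c2nn(-c3cccc(NC(=O)Nc4ccc(Cl)c(C(F)(F)F)c4)c3)cc2-c2ccncc2)c1` has not yet been measured in this assay. It differs from compound 1 by methyl in place of hydrogen on an oxygen on an aromatic ring. For the measured compounds named here, none of the measured steps touches this part of the molecule: the only step known, from trifluoromethyl to chloro on a different aromatic ring, was a number 2 percentage points higher from compound 1 to compound 2 (within the scatter). The data therefore give no ground to expect a step beyond the scatter in either direction, and the expected step is a number 1 percentage points lower from compound 1 to compound 3 (within the scatter). For compound 3 the estimate is 100%, with a range from 86% to 112%.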

Compound 3, a percentage reported as activity, at one concentration (the size of the read-out at that concentration, not a potency): 100%
Compound 3: middle estimate and measured number agree at the digits printed; the measured number falls inside the stated range.
By their numbers in this assay, from the lowest: compounds 3, 1 and 2 (each within the scatter of the next).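

In this assay, the change from hydroxy to methoxy is a number 1 percentage points lower from compound 1 to compound 3 (within the scatter). For the compounds shown here, this is the first reading at this position, which the earlier pair left untouched: on the 3-chloro-5-hydroxyphenyl group, methyl can replace the hydrogen on the oxygen with no difference that this read-out can resolve, although all three compounds stand at essentially the level of untreated cells, so a change that would weaken the effect could not show here. Nothing available explains this result or connects it to any property of the group.

The compounds shown leave open whether an amine, a carboxylic acid or a longer chain such as ethoxy at this place would give a number apart from these. They also leave open whether any change on the shared core would move the number away from the level of untreated cells.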